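Bromine to difluoro on the chalcone aryl ring

The source may hold more compounds than are shown below. What is called first, only, known or untested is meant among the compounds shown, and "the series" means these compounds.

Measured compounds:
compound 1 `O=C(COc1ccc(C(=O)/C=C/c2cccc(Br)c2)cc1)N[C@H]1CCOC1=O`: 11900 nM
compound 2 `O=C(CNc1cccc(Cl)c1)N[C@H]1CCOC1=O`: > 64000 nM
compound 3 `O=C1OCC[C@@H]1NC(=S)SCCOc1ccc([N+](=O)[O-])cc1`: > 100000 nM

In a functional assay on MGC-803 cells (Homo sapiens) for antiproliferative activity, read by MTT assay, with a stated time of 72 h (on this read-out higher numbers stand for weaker inhibition and lower numbers for stronger inhibition), compound 1 gives 11900 nM, the only numerical result among the three. Compound 2 reaches only a limit of the assay, at > 64000 nM, as described by the limit of > 64000 nM in this assay, at which 1 of the 3 values shown sits. Compound 3 likewise stops at a limit, > 100000 nM, as described by the limit of > 100000 nM in this assay, at which 1 of the 3 values shown sits. Compound 4 `O=C(COc1ccc(C(=O)/C=C/c2ccc(F)c(F)c2)cc1)N[C@H]1CCOC1=O` has not been measured yet. It differs from compound 1 in one place: 3,4-difluorophenyl in place of 3-bromophenyl on a double-bonded chain carbon bound to a double-bonded chain carbon. Within the data shown here, no measured pair among the three compounds shows what such a change does, so no direction is given by the data. The step from compound 1 to compound 4 in this assay is expected to stay within the scatter, a 1.0-fold higher number from compound 1 to compound 4 (0.00 log units; within the scatter). Compound 4 is therefore estimated at 12000 nM, between 5000 nM and 30000 nM.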

Compound 4, half-maximal inhibitory concentration: > 64000 nM
Compound 4 gave a limit, no number (the forecaster's own chance of this, stated with the estimate: 5%); at least 5.3-fold (0.72 log units) between middle value and limit.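

In this assay, the step from 3-bromophenyl to 3,4-difluorophenyl on a double-bonded chain carbon bound to a double-bonded chain carbon gives an at least 5.3-fold higher number from compound 1 to compound 4 (0.73 log units; beyond the scatter). Among these compounds, this is the first sign that the group at this place matters, and here the change weakens inhibition. Compound 4 reaches only a limit of the assay, so the step has a lower bound but no full size: the limit of > 64000 nM in this assay, at which 2 of the 4 values shown sit.

From the compounds shown here alone, whether the step follows from losing the bromine or from gaining the two fluorines stays open. So does what a plain phenyl or a methoxy-bearing phenyl would give at this place.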